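The compounds below may be only part of what the source reports. "The series", "measured", "known", "first", "only" and "open" are said of these compounds alone.

Measured so far in an ADME assay on the whole organism (thoracic aorta) with Rattus norvegicus as the target; a higher number here means a larger maximal response, a lower number a smaller maximal response: compound 1 `S=C=Nc1ccc(CC2=NCCN2)cc1` gives 118%; compound 2 `Nc1ccc(CC2=NCCN2)cc1` gives 69%.

Compound 2 stands lowest of the two numbers in this assay; its nearest neighbour is compound 1, and the step from compound 1 to compound 2 was a number 49 percentage points lower from compound 1 to compound 2 (beyond the scatter), a large drop beyond the scatter, on exchange of one nitrogen atom for a group of three heavy atoms on an aromatic carbon.

Compound 3 `O=C(CCl)Nc1ccc(CC2=NCCN2)cc1` is not yet measured. It differs from compound 2 by (chloromethyl)carbonyl in place of hydrogen on a nitrogen on an aromatic ring. Among the measured compounds shown here, only the step from compound 1 to compound 2 bears on this, and only loosely: it shows that a larger group in place of the bare amino at this point of the core went with the higher number in this assay, by a large margin. The change to compound 3 again replaces a hydrogen on that nitrogen with a larger group, so an increase of moderate size is expected, though not necessarily as large as the measured step.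

For compound 3 the expected step is a number 23 percentage points higher from compound 2 to compound 3 (beyond the scatter), giving an estimate of 92% with a range of 60% to 125%.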

Compound 3, largest response reached (Emax), in percent of the reference or control that the assay uses: 41%
The estimate for compound 3 lay 51 percentage points above the measured number, outside the stated range (below it).
By their numbers in this assay, from the lowest: compound 3; then compound 2; then compound 1.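

In this assay, a larger group on this nitrogen does not by itself raise the number: (chloromethyl)carbonyl in place of hydrogen on a nitrogen on an aromatic ring gives a number 28 percentage points lower from compound 2 to compound 3 (beyond the scatter), leaving compound 3 lowest of the three. Exchanging one larger group for the other on the aromatic carbon gives a number 77 percentage points lower from compound 1 to compound 3 (beyond the scatter), so among these three compounds the number follows the kind of group and not its size, with the larger group of compound 3 going against any trend with size. Nothing measured here accounts for the opposite directions of these changes.

The compounds shown leave open whether the drop belongs to the carbonyl on the nitrogen or to the chlorine. A plain acetyl group, or a longer chain ending in chlorine, on the same nitrogen would separate these two readings.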